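The compounds below may be only part of what the source reports. "The series", "measured", "known", "first", "only" and "open" are said of these compounds alone.

Compound 1 `O=C(Nc1ccc(Cl)c(F)c1)c1ccc2[nH]ncc2c1` gives in an assay on cells for inhibition of Amine oxidase [flavin-containing] A (Rattus norvegicus) (a lower number here means a stronger inhibitor, a higher number a weaker inhibitor), a limit, > 10000 nM.
Compound 2 `O=C(Nc1ccc(F)c(Cl)c1)c1ccc2cn[nH]c2c1` gives in this assay a limit, > 10000 nM.
Compound 3 `O=C(Nc1ccc(F)c(F)c1)c1ccc2cn[nH]c2c1` gives in this assay a limit, > 10000 nM.

None of these three is a true number: every value sits at the edge of what this assay can report (the limit of > 10000 nM in this assay, at which 3 of the 3 values shown sit). Compound 2 therefore stands nowhere on a scale; only a limit is known for it, as for its two neighbours. Among the measured compounds shown here, the single step between measured compounds, from compound 2 to compound 3 (a step that the two limits leave unreadable from compound 2 to compound 3), cannot be sized, since both of its ends are limits.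

Compound 4 `O=C(Nc1ccc(O)c(Cl)c1)c1ccc2cn[nH]c2c1` differs from compound 2 by hydroxy in place of fluoro on an aromatic carbon. For the measured compounds named here, no measured step involves an exchange of this kind, and the one step recorded is unreadable, so the measurements give no expectation of a step of any size or direction in this assay beyond the scatter. With nothing pointing away from the limit, compound 4 is expected near 20000 nM, within 4000 nM to 100000 nM, most likely again reported only as a limit. The step this estimate implies, a step that the limit leaves unreadable from compound 2 to compound 4, is an expectation and no more.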

Compound 4, half-maximal inhibitory concentration: > 10000 nM
Compound 4: no number, only a limit; the forecaster's own chance of this, stated with the estimate: 75%; the middle value is on the limit's open side.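

Among the compounds shown here, no step from compound 2 to compound 4 can be read in this assay, since both ends are limits and not numbers: the limit of > 10000 nM in this assay, at which 4 of the 4 values shown sit. The compounds shown leave open how strongly any of the four inhibits, and whether exchanging fluoro for hydroxy changes that at all.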